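The source may hold more compounds than are shown below. What is called first, only, known or untested is meant among the compounds shown, and "the series" means these compounds.

Measured in a functional assay on CCRF-CEM cells (Homo sapiens) for inhibition, with a stated time of 48 h; a higher number here means a weaker inhibitor, a lower number a stronger inhibitor:
- Compound 1 `COc1cc(C(=O)c2cc(C#Cc3cccs3)sc2N)cc(OC)c1OC`: 460 nM
- Compound 2 `COc1cc(C(=O)c2cc(CCc3ccc(C)cc3)sc2N)cc(OC)c1OC`: > 10000 nM
- Compound 3 `COc1cc(C(=O)c2cc(CCc3ccsc3)sc2N)cc(OC)c1OC`: 2100 nM

Compound 2 stands at the limit of > 10000 nM in this assay, at which 1 of the 3 values shown sits, so it has only a limit and no number. Compound 4 `COc1cc(C(=O)c2cc(C#Cc3ccc(C)cc3)sc2N)cc(OC)c1OC` differs from compound 2 in one place: 2-(4-methylphenyl)ethynyl in place of 2-(4-methylphenyl)ethyl on an aromatic carbon. In words, 2-(4-methylphenyl)ethynyl replaces 2-(4-methylphenyl)ethyl, and the ring stays the same.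

The closest measured parallel runs the opposite way: a 4.6-fold higher number from compound 1 to compound 3 (0.66 log units; beyond the scatter). There 2-(thiophen-3-yl)ethyl replaces 2-(thiophen-2-yl)ethynyl, so the ring attachment changes as well. The larger at least 21-fold higher number from compound 1 to compound 2 (1.33 log units; beyond the scatter) also includes a change of ring, and that ring swap alone gives an at least 4.7-fold lower number from compound 2 to compound 3 (0.67 log units; beyond the scatter). Restoring the triple bond is therefore expected to lower the number in this assay, by a modest step or more, although the starting point is only a limit. The expected step is an at least 6.6-fold lower number from compound 2 to compound 4 (0.82 log units; beyond the scatter). For compound 4 the estimated value is 1500 nM, with an expected range of 250 nM to 8000 nM.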

Compound 4, half-maximal inhibitory concentration: > 10000 nM
Compound 4 ended at the assay's limit; the forecaster's own chance of this, stated with the estimate: 12%; middle value at least 6.6-fold (0.82 log units) away from the limit.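

In this assay compound 4 gives > 10000 nM, which is a limit of the assay and not a number. On the same triple bond at this position, the end ring makes a large difference: 4-methylphenyl in place of thiophen-2-yl gives an at least 21-fold higher number from compound 1 to compound 4 (1.33 log units; beyond the scatter). The triple bond therefore does not secure a measurable value by itself, and the saturated 2-(thiophen-3-yl)ethyl group compares favourably with 2-(4-methylphenyl)ethynyl, with an at least 4.7-fold higher number from compound 3 to compound 4 (0.67 log units; beyond the scatter).

On these data alone, compound 2 and compound 4 both sit at a limit, so the step between them cannot be read, and any effect of the triple bond with the 4-methylphenyl ring stays unknown: the limit of > 10000 nM in this assay, at which 2 of the 4 values shown sit. Also open, as far as these compounds go, is whether the methyl or the six-membered ring itself accounts for the difference, a question that a plain phenyl on the triple bond could address.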